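The compounds below may be only part of what the source reports. "The series", "measured", "known", "first", "only" and "open" are said of these compounds alone.

The series is built on one shared core, carried by compound 1 `N=C(N)c1ccc(-c2ccc(-c3cc(Cl)cc(Cl)c3)s2)cc1` and compound 2 `COc1cc(OC)cc(-c2ccc(-c3ccc(C(=N)N)c(F)c3)s2)c1`. In a functional assay on A549 cells (Homo sapiens) for inhibition, read by sulforhodamine B assay, with a stated time of 48 h (on this read-out higher numbers stand for weaker inhibition of growth and lower numbers for stronger inhibition of growth), compound 1 gives 1520 nM, while in this assay compound 2 gives 400 nM. Compound 2 therefore stands at the lower of the two numbers measured, and its gap to compound 1 lies beyond the scatter of repeated measurements of this kind. Going by the values given here, the two compounds differ in more than one place, so what their pair shows is only that the two values stand apart; no single change can be read from it.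

Compound 3 `COc1cc(OC)cc(-c2ccc(-c3ccc(C(=N)N)cc3)s2)c1` has not yet been measured in this assay. It differs from compound 2 in one place: hydrogen in place of fluoro on an aromatic carbon. Among the compounds with values here, no step between two measured compounds isolates this change, so nothing measured here tells how much it matters. He expects the step from compound 2 to compound 3 to be small, a 1.4-fold higher number from compound 2 to compound 3 (0.14 log units; within the scatter), within the usual scatter, with no clear direction. For compound 3 he estimates 550 nM in this assay, with a range from 200 nM to 1500 nM.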

Compound 3, concentration for 50% growth inhibition: 2580 nM
Compound 3: the middle estimate sits 4.7-fold (0.67 log units) below what was measured; the measured number lies above the stated range.
By their numbers in this assay, from the lowest: compound 2; then compounds 1 and 3 (each within the scatter of the next).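

Going by these compounds alone, replacing fluoro with hydrogen gives a 6.5-fold higher number from compound 2 to compound 3 (0.81 log units; beyond the scatter) in this assay and is the first step here that isolates this position, on the aromatic carbon ortho to a group of 3 heavy atoms. It shows that this single fluorine atom is not a silent substituent in this pair, as its loss moves the number toward weaker inhibition of growth, something the earlier comparison of two compounds differing in more than one place could not show. Nothing available explains why the step has this size.

The compounds shown leave open whether this effect is particular to fluoro or whether a hydroxyl, an amine or a nitrile on the same aromatic carbon would give a number like that of compound 2 (400 nM). They also leave open whether the same exchange would carry a step of similar size on the core of compound 1, which has chloro groups where compound 2 and compound 3 have methoxy groups.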